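Toward a 4-phenylbutyl amide on a shared core

A few compounds are considered here, and "the series" means these few. Any claim that something is new, unique, unknown or untested is made for them only; others in the source may bear on it.

Measured so far in an ADME assay on L6 cells (Rattus norvegicus) for cytotoxicity; a lower number here means a stronger inhibitor, a higher number a weaker inhibitor:
- compound 2 `O=C(NCCCN1CCN(CCCNc2ccnc3cc(Cl)ccc23)CC1)c1cccc(OC(F)(F)F)c1`: 8500 nM
- compound 3 `CC(C)=CC(=O)NCCCN1CCN(CCCNc2ccnc3cc(Cl)ccc23)CC1`: 30000 nM
- compound 1 `CC(C)CC(=O)NCCCN1CCN(CCCNc2ccnc3cc(Cl)ccc23)CC1`: "not determined" (no result reported)

All three compounds share the same core and differ only in the group on the amide carbonyl carbon. Compound 3 stands with the highest number of the two measured values, and its nearest neighbour is compound 2, which sits a 3.5-fold higher number from compound 2 to compound 3 (0.55 log units; beyond the scatter). Within the data shown here, that single step is the only measured comparison that bears on the present change, in which compound 4 `O=C(CCCCc1ccccc1)NCCCN1CCN(CCCNc2ccnc3cc(Cl)ccc23)CC1` arises from compound 3 through (4-phenylbutyl in place of 2-methylprop-1-en-1-yl on a carbonyl carbon). In compound 2 an aromatic ring on the carbonyl carbon went with a lower number than the short branched alkenyl chain of compound 3; compound 4 also brings an aromatic ring, though at the end of a longer chain. A modest step downward is therefore expected, roughly a 3.0-fold lower number from compound 3 to compound 4 (0.48 log units; beyond the scatter). For compound 4 the estimate in this assay is 10000 nM, with a plausible range from 4000 nM to 25000 nM.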

Compound 4, half-maximal inhibitory concentration: 9400 nM
Beside the measured number, compound 4's estimate is 1.1-fold (0.03 log units) above it; the measured number falls inside the stated range.
By their numbers in this assay, from the lowest: compounds 2 and 4 (each within the scatter of the next); then compound 3.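

In this assay, 4-phenylbutyl in place of 2-methylprop-1-en-1-yl on the carbonyl carbon gives a 3.2-fold lower number from compound 3 to compound 4 (0.50 log units; beyond the scatter). Set against the 3-(trifluoromethoxy)phenyl group of compound 2, the same 4-phenylbutyl group gives a 1.1-fold higher number from compound 2 to compound 4 (0.04 log units; within the scatter), so these two ring-bearing groups cannot be told apart here, and among the measured compounds, only compound 3 has no ring and it has the highest number. No evidence on the cause of this difference is available.

As far as these compounds go, compound 2 and compound 4 each carry both a ring and a larger group than compound 3, so it remains open whether the ring or the size goes with the lower number. A plain octyl chain without a ring could separate the two, while compound 1 gives "not determined" (no result reported) and offers no help.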